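Thiazole for Thiophene at the Ether Chain End

The source may report more compounds than this note shows. Statements on the series, on what has been measured and on what is new or still open speak of the compounds shown alone.

Going by the values given here, compound 3 `Cc1ccc(CCOc2ccc(-c3c(C)nc(C)c([C@H](OC(C)(C)C)C(=O)O)c3N3CCC(C)(C)CC3)cc2)s1` is one of three compounds measured in an ADME assay on microsomes from liver (Homo sapiens) for metabolic stability, read by LC-MS, tested at 0.5 uM; on this read-out lower numbers stand for a shorter-lived compound and higher numbers for a longer-lived compound. In this assay compound 3 sits at a limit of the read-out rather than at a number, > 2 h. Compound 1 `Cc1nc(C)c([C@H](OC(C)(C)C)C(=O)O)c(N2CCC(C)(C)CC2)c1-c1ccc(OCCc2ccc(F)c(F)c2)cc1` likewise gives only a limit, > 2 h. Compound 2 `Cc1nc(C)c([C@H](OC(C)(C)C)C(=O)O)c(N2CCC(C)(C)CC2)c1-c1ccc(OC2COCC2c2ccc(F)cc2)cc1` gives a number, 0.783 h. Compound 1 and compound 3 both sit at the limit of > 2 h in this assay, at which 2 of the 3 values shown sit. Among the measured steps, an at least 2.5-fold higher number from compound 2 to compound 3 (0.40 log units; beyond the scatter) and an at least 2.5-fold lower number from compound 1 to compound 2 (0.40 log units; beyond the scatter), both of which exchange the whole group on the aromatic oxygen; a step that the two limits leave unreadable from compound 1 to compound 3.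

Compound 4 `Cc1nc(CCOc2ccc(-c3c(C)nc(C)c([C@H](OC(C)(C)C)C(=O)O)c3N3CCC(C)(C)CC3)cc2)cs1` is not yet measured. It differs from compound 3 only in 2-methyl-1,3-thiazol-4-yl in place of 5-methylthiophen-2-yl on a saturated chain carbon, two bonds along the chain from an oxygen on an aromatic ring. Among the compounds with values here, no measured step exchanges one five-membered aromatic ring for another at this place, and the closest comparison, from compound 1 to compound 3, is unreadable because both values are limits. With the chain and the rest of compound 3 unchanged, the expectation is a step no larger than the scatter, an at least 1.2-fold lower number from compound 3 to compound 4 (0.09 log units; that floor lies within the scatter), while allowing that the thiazole may bring the value down from the limit. Compound 4 is therefore estimated at 1.6 h, with a range from 0.6 h to 2 h.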

Compound 4, half-life: 0.683 h
Estimate against measurement, compound 4: 2.3-fold (0.37 log units) above; measured number inside the range.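

In this assay, 2-methyl-1,3-thiazol-4-yl in place of 5-methylthiophen-2-yl is an at least 2.9-fold lower number from compound 3 to compound 4 (0.46 log units; beyond the scatter), so this place, on a saturated chain carbon two bonds along the chain from an oxygen on an aromatic ring, responds to an exchange of one five-membered aromatic ring for another, which the unreadable step between the two limits could not show. The exchange for 3,4-difluorophenyl at the same place is an at least 2.9-fold lower number from compound 1 to compound 4 (0.46 log units; beyond the scatter), while the exchange of the whole group on the aromatic oxygen is a 1.1-fold lower number from compound 2 to compound 4 (0.06 log units; within the scatter), so the ethyl chain alone does not keep the number at the limit, and compound 4 cannot be told apart from compound 2 here. Both readable lower steps start from a limit rather than a number, so their sizes are floors only: the limit of > 2 h in this assay, at which 2 of the 4 values shown sit.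

Which feature of the entering ring carries the step stays open, as it brings one more hetero atom in the same exchange, and an oxazole or a pyridine at this place would bear on that question. On these data alone, the true half-lives of compound 1 and compound 3 also stay open.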